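The compounds below may be only part of what the source reports. "The series", "measured", "known", "first", "only" and "open" are said of these compounds alone.

Four urea-type compounds share a core that carries a pyrazole-bearing benzyl group on an amide-type nitrogen, and they differ in the ring on that nitrogen and in the aromatic ring on the other side of the urea. Compound 1 `O=C(Nc1c(F)cc(F)cc1F)N(Cc1cccc(-c2cc[nH]n2)c1)C1CCCCCC1` carries a cycloheptyl ring, and in a functional assay on a cell-free system (plasma) with sterol O-acyltransferase, Soat (Rattus norvegicus) as the target (on this read-out lower numbers stand for an effect already at smaller amounts and higher numbers for an effect only at larger amounts of compound), compound 1 gives 0.062 mg/kg. Compound 2 `Cc1cc(C)c(NC(=O)N(Cc2cccc(-c3cc[nH]n3)c2)C2CCCCC2)c(C)c1` carries a cyclohexyl ring and a trimethylphenyl group, and in this assay compound 2 gives 0.12 mg/kg. Compound 3 `Cc1cc(C)c(NC(=O)N(Cc2cccc(-c3cc[nH]n3)c2)C2CCCC2)c(C)c1` keeps the trimethylphenyl group but carries a cyclopentyl ring. For compound 3 the result in this assay is only a limit of the assay, < 1 mg/kg, so compound 3 stands without a number of its own. For that reason the step from compound 2 to compound 3 is a step that the limit leaves unreadable from compound 2 to compound 3, as the limit of < 1 mg/kg in this assay, at which 1 of the 3 values shown sits, makes clear.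

Compound 4 `Cc1cc(C)c(NC(=O)N(Cc2cccc(-c3cc[nH]n3)c2)C2CCCCCC2)c(C)c1` is the next member: cycloheptyl in place of cyclopentyl on an amide-type nitrogen. Among the measured compounds shown here, no measured step reads on this change, since the only step involving compound 3 is hidden by the limit. What remains is that compound 2, with the cyclohexyl ring, sits at 0.12 mg/kg, and compound 1, with the same cycloheptyl ring but a different aromatic group, sits at 0.062 mg/kg. On that basis compound 4 is expected to land in this assay near those two, at an estimated 0.09 mg/kg, with a range from 0.03 mg/kg to 0.3 mg/kg; the step from compound 3 to compound 4 is then expected to be a step that the limit leaves unreadable from compound 3 to compound 4.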

Compound 4, dose for half-maximal effect: 0.097 mg/kg
The estimate for compound 4 lay 1.1-fold (0.03 log units) below the measured number; measured number inside the range.
By their numbers in this assay, from the lowest: compounds 1, 4 and 2 (each within the scatter of the next).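

With the 2,4,6-trimethylphenyl group held constant, putting cycloheptyl in place of cyclohexyl on the amide-type nitrogen gives a 1.2-fold lower number from compound 2 to compound 4 (0.09 log units; within the scatter) in this assay, so these two rings cannot be told apart on this read-out, even though the ring grows by one carbon. Among the compounds shown here, with the cycloheptyl ring held constant, the new compound also gives the first clean comparison of the two aromatic groups: 2,4,6-trimethylphenyl in place of 2,4,6-trifluorophenyl gives a 1.6-fold higher number from compound 1 to compound 4 (0.19 log units; within the scatter), so that exchange also makes no readable difference. Compound 3 has only a limit, so the steps that link it to the other compounds cannot be read and the cyclopentyl ring remains unplaced against the larger rings: the limit of < 1 mg/kg in this assay, at which 1 of the 4 values shown sits.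

Going by these compounds, how far this tolerance on the nitrogen extends remains open, for example whether an open chain such as n-hexyl or a ring carrying an amine, such as a piperidine, would read like cyclohexyl and cycloheptyl. Also open is whether the aromatic ring on the other side of the urea would accept a carboxylic acid or a plain unsubstituted phenyl in place of the two groups shown.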